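From benzoyl to acetyl on a shared core

The source may hold more compounds than are shown below. What is called first, only, known or untested is meant among the compounds shown, and "the series" means these compounds.

Three compounds share one core and differ only in the ring-bearing group on a carbonyl carbon: compound 1 `C=C1CC[C@@H]2[C@](C)(CO)[C@H](OC(=O)c3cccnc3)CC[C@@]2(C)[C@@H]1C/C=C1\C=COC1=O`, compound 2 `C=C1CC[C@@H]2[C@](C)(CO)[C@H](OC(=O)c3cccs3)CC[C@@]2(C)[C@@H]1C/C=C1\C=COC1=O` and compound 3 `C=C1CC[C@@H]2[C@](C)(CO)[C@H](OC(=O)c3ccccc3)CC[C@@]2(C)[C@@H]1C/C=C1\C=COC1=O`. In an ADME assay on HepG2 2.2.15 cells (Homo sapiens) for cytotoxicity, read by MTT assay (a lower number here means that less compound is tolerated, a higher number that more compound is tolerated), compound 1 gives 337000 nM, compound 2 gives 257000 nM and compound 3 gives 103000 nM. Compound 3 therefore has the lowest number of the three.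

The next compound, compound 4 `C=C1CC[C@@H]2[C@](C)(CO)[C@H](OC(C)=O)CC[C@@]2(C)[C@@H]1C/C=C1\C=COC1=O`, keeps the core but has methyl in place of phenyl on a carbonyl carbon. Cut one bond further out, this reads benzoyl to acetyl.

Two measured steps end at phenyl and so bear on this change: a 3.3-fold lower number from compound 1 to compound 3 (0.51 log units; beyond the scatter) and a 2.5-fold lower number from compound 2 to compound 3 (0.40 log units; beyond the scatter). Both are modest. By contrast, a 1.3-fold lower number from compound 1 to compound 2 (0.12 log units; within the scatter), so those two groups cannot be told apart. Read in reverse, leaving phenyl raised the number both times, but each replacement was a ring, and methyl is not. For the measured compounds named here, no measured compound here lacks a ring at this place, which makes the guide a weak one.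

A modest rise is still what is expected, and the estimated change is a 2.2-fold higher number from compound 3 to compound 4 (0.35 log units; beyond the scatter). For compound 4 the estimated value is 230000 nM, with an expected range from 80000 nM to 600000 nM.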

Compound 4, half-maximal cytotoxic concentration: 872000 nM
Compound 4: the middle estimate sits 3.8-fold (0.58 log units) below what was measured, and the stated range ends below it.
By their numbers in this assay, from the lowest: compound 3; then compounds 2 and 1 (each within the scatter of the next); then compound 4.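

In this assay, for the compounds shown here, methyl, the only group here without a ring on this carbonyl carbon, gives a higher number than each of the rings: an 8.5-fold higher number from compound 3 to compound 4 (0.93 log units; beyond the scatter), a 3.4-fold higher number from compound 2 to compound 4 (0.53 log units; beyond the scatter) and a 2.6-fold higher number from compound 1 to compound 4 (0.41 log units; beyond the scatter). The earlier compounds shown here compared only rings with one another, and the largest step among them, a 3.3-fold lower number from compound 1 to compound 3 (0.51 log units; beyond the scatter), is smaller than the step from phenyl to methyl, so this position allows a wider spread of numbers than those compounds revealed. Nothing available here explains why the number rises when the ring is replaced by methyl.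

With only one ring-free group, the compounds shown cannot separate the loss of a ring from the loss of heavy atoms, since methyl differs from phenyl in both. A longer chain such as ethyl or butyl on the same carbonyl carbon would help to tell these apart, and an amine or a carboxylic acid at the end of such a chain would show whether the number depends on more than the absence of a ring.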